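The compounds below may be only part of what the source reports. "The series", "measured", "known", "first", "only" and "open" are said of these compounds alone.

Series notes. Compound 1 `CNC(=O)c1cc(Oc2ccc(NC(=O)c3nn(-c4ccc(Br)cc4F)c(=O)cc3C)cc2F)ccn1` and compound 2 `CNC(=O)c1cc(Oc2ccc(NC(=O)c3nn(-c4ccccc4OC(F)(F)F)c(=O)cc3C)cc2F)ccn1` share one core; compound 3 `Cc1cc(=O)n(-c2ccc(Br)cc2F)nc1C(=O)Nc1ccc(Oc2ncnc3sccc23)cc1` and compound 4 `Cc1cc(=O)n(-c2ccccc2OC(F)(F)F)nc1C(=O)Nc1ccc(Oc2ncnc3sccc23)cc1` share another, and the difference between the two cores is not broken down here. In a functional assay on A549 cells (Homo sapiens) for cytotoxicity, read by MTT assay, with a stated time of 72 h (on this read-out lower numbers stand for stronger inhibition and higher numbers for weaker inhibition), compound 1 gives 7930 nM. For compound 2 the value in this assay is a limit of the assay, > 40000 nM. In this assay compound 3 gives 12800 nM, which sits within the usual scatter of compound 1, so no order between these two is drawn.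

Among the compounds with values here, the one change made twice is 2-(trifluoromethoxy)phenyl in place of 4-bromo-2-fluorophenyl on an aromatic nitrogen on the core of compound 1 and 2-(trifluoromethoxy)phenyl in place of 4-bromo-2-fluorophenyl on an aromatic nitrogen on the core of compound 3; the two place descriptions read alike, so it is the same kind of change on each core. On the first core it gave an at least 5.0-fold higher number from compound 1 to compound 2 (0.70 log units; beyond the scatter), its full size open because of the limit of > 40000 nM in this assay, at which 1 of the 3 values shown sits.

For the second core a step of the same direction is expected, a 4.7-fold higher number from compound 3 to compound 4 (0.67 log units; beyond the scatter), resting on an at least 5.0-fold higher number from compound 1 to compound 2 (0.70 log units; beyond the scatter). Compound 4 is therefore estimated at 60000 nM, with a range from 20000 nM to 160000 nM, and a reported limit rather than a number is the likelier outcome.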

Compound 4, half-maximal inhibitory concentration: 15500 nM
Compound 4: the middle estimate sits 3.9-fold (0.59 log units) above what was measured; measured number below the stated range.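

In this assay, 2-(trifluoromethoxy)phenyl in place of 4-bromo-2-fluorophenyl on the core of compound 3 gave a 1.2-fold higher number from compound 3 to compound 4 (0.08 log units; within the scatter), so the step seen on the core of compound 1 did not carry over in size: the same change on two cores in this assay, an at least 5.0-fold higher number (0.70 log units; beyond the scatter) from compound 1 to compound 2 and a 1.2-fold higher number (0.08 log units; within the scatter) from compound 3 to compound 4, at least 4.1-fold (0.61 log units) apart, beyond the scatter of two such steps. On these data alone, compound 2 is reported only as a limit, > 40000 nM, so the size of the first step and of the gap between the two steps stays open on the upper side: the limit of > 40000 nM in this assay, at which 1 of the 4 values shown sits. These two pairs show that in this series the size of this change depends on the core it is made on, but they do not show which part of the cores is responsible, and they give no rule for other changes.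

As far as these compounds go, whether a plain phenyl or a methyl group on the aromatic nitrogen would also give different steps on the two cores remains open. Also open, from the compounds shown here alone, is whether a 4-bromo-2-fluorophenyl to 2-(trifluoromethoxy)phenyl change would behave the same way on a third core.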